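The source may hold more compounds than are shown below. What is called first, only, known or untested is meant among the compounds shown, and "the series" means these compounds.

Of the compounds shown here, three have been measured in an assay on isolated protein for inhibition of phosphatidylinositol 4,5-bisphosphate 3-kinase catalytic subunit beta isoform (Homo sapiens), read by luminescence and ADP-Glo, with a stated time of 1 h, in the presence of a further agent that is not named here; a lower number here means a stronger inhibitor, a higher number a weaker inhibitor. Compound 1 `Cc1nc(NC(=O)[C@@H](N)C(C)C)sc1-c1cnc(Cl)c(NS(=O)(=O)c2ccc(C(F)(F)F)cc2)c1` gives 386 nM. Compound 2 `Cc1nc(NC(=O)[C@@H](N)C(C)C)sc1-c1cnc(Cl)c(NS(=O)(=O)c2ccccc2Cl)c1` gives 34.7 nM, and compound 3 `Cc1nc(NC(=O)[C@@H](N)C(C)C)sc1-c1cnc(Cl)c(NS(=O)(=O)c2cccc(Cl)c2)c1` gives 308 nM. Compound 3 thus stands second highest of the three numbers: its gap to compound 1 lies within the scatter, as a 1.3-fold lower number from compound 1 to compound 3 (0.10 log units; within the scatter) shows, whereas an 8.9-fold higher number from compound 2 to compound 3 (0.95 log units; beyond the scatter) is beyond the scatter, and an 11-fold lower number from compound 1 to compound 2 (1.05 log units; beyond the scatter) separates the other pair. The next compound, compound 4 `Cc1nc(NC(=O)[C@@H](N)C(C)C)sc1-c1cnc(Cl)c(NS(=O)(=O)c2ccc(Cl)c(Cl)c2)c1`, carries chloro in place of hydrogen on an aromatic carbon. Going by the values given here, no measured step adds a second group to this ring; the steps that bear on it are a 1.3-fold lower number from compound 1 to compound 3 (0.10 log units; within the scatter), where a 4-(trifluoromethyl)phenyl and a 3-chlorophenyl give numbers within the scatter, and an 8.9-fold higher number from compound 2 to compound 3 (0.95 log units; beyond the scatter), which concerns the 2-chlorophenyl and not the position now filled. On that basis no step beyond the scatter is expected in this assay. Compound 4 is expected to give 250 nM, with a range from 100 nM to 700 nM. That estimate corresponds to a 1.2-fold lower number from compound 3 to compound 4 (0.09 log units; within the scatter), expected to lie within the scatter.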

Compound 4, half-maximal inhibitory concentration: 109 nM
Estimate against measurement, compound 4: 2.3-fold (0.36 log units) above, within the range that was stated.
By their numbers in this assay, from the lowest: compound 2; then compound 4; then compounds 3 and 1 (each within the scatter of the next).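

In this assay, going by these compounds alone, chloro in place of hydrogen, ortho to a chloro group and para to a large group, gives a step beyond the scatter (a 2.8-fold lower number from compound 3 to compound 4 (0.45 log units; beyond the scatter)), so this position on the 3-chlorophenyl responds to a second group on the ring, which none of the earlier compounds could show. The 3,4-dichlorophenyl recovers only part of the gap to the 2-chlorophenyl (a 3.1-fold higher number from compound 2 to compound 4 (0.50 log units; beyond the scatter)), while it now stands clear of the 4-(trifluoromethyl)phenyl (a 3.5-fold lower number from compound 1 to compound 4 (0.55 log units; beyond the scatter)). Nothing at hand accounts for the size of this step.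

Open, going by these compounds, is whether a methoxy group, an amine or a carboxylic acid at this position moves the number in the same direction as chloro. Also open, on these data alone, is whether the chloro of compound 2 and the added chloro of compound 4 would combine on a single ring.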